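Moving two methoxy groups on a weak compound

A few compounds are considered here, and "the series" means these few. Any claim that something is new, unique, unknown or untested is made for them only; others in the source may bear on it.

Measured in a functional assay on K562 cells (Homo sapiens) for antiproliferative activity, with a stated time of 72 h; on this read-out higher numbers stand for weaker inhibition and lower numbers for stronger inhibition:
Compound 1 (`OC[C@H]1O[C@@H](n2cnc3c(NCc4ccc(F)cc4)ncnc32)[C@H](O)[C@@H]1O`) gives 2700 nM
Compound 2 (`OC[C@H]1O[C@@H](n2cnc3c(NCc4ccccc4Cl)ncnc32)[C@H](O)[C@@H]1O`) gives 64000 nM
Compound 3 (`COc1cccc(CNc2ncnc3c2ncn3[C@@H]2O[C@H](CO)[C@@H](O)[C@H]2O)c1OC`) gives > 166000 nM (a limit)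

Compound 3 is the weakest here, and its > 166000 nM is a limit of the assay, not a number. Compound 4 (`COc1cc(CNc2ncnc3c2ncn3[C@@H]2O[C@H](CO)[C@@H](O)[C@H]2O)cc(OC)c1`) has the same atoms joined differently (3,5-dimethoxyphenyl in place of 2,3-dimethoxyphenyl on a saturated chain carbon bound to a nitrogen on an aromatic ring). Swapping the group at this place has moved the number strongly (a 24-fold higher number from compound 1 to compound 2 (1.37 log units; beyond the scatter); an at least 61-fold higher number from compound 1 to compound 3 (1.78 log units; beyond the scatter)) and less strongly (an at least 2.5-fold higher number from compound 2 to compound 3 (0.41 log units; beyond the scatter)). None of these steps only rearranges methoxy groups, so they give size, not direction. Compound 4 is expected to stay weak, far from compound 1 (2700 nM). The expected move is modest and towards a lower number (an at least 1.6-fold lower number from compound 3 to compound 4 (0.22 log units; that floor lies within the scatter)). In this assay the estimate for compound 4 is 100000 nM (range 25000 nM to 300000 nM).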

Compound 4, half-maximal inhibitory concentration: > 166000 nM
Compound 4: no number, only a limit (the forecaster's own chance of this, stated with the estimate: 45%); at least 1.6-fold (0.22 log units) between middle value and limit.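

In this assay, compound 4 gives no number, and rearranging the two methoxy groups does not lift it off the limit: the limit of > 166000 nM in this assay, at which 2 of the 4 values shown sit.

With limits on both sides, the step between compound 3 and compound 4 cannot be read, so the effect of this rearrangement has no measured size. The 3,5-dimethoxyphenyl group still gives an at least 2.5-fold higher number from compound 2 to compound 4 (0.41 log units; beyond the scatter) and an at least 61-fold higher number from compound 1 to compound 4 (1.78 log units; beyond the scatter).

Going by these compounds, whether the two dimethoxyphenyl groups truly differ stays open. On these data alone, it is also open whether an amine or a carboxylic acid on the phenyl ring would give a readable number.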